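Heteroaryl swap on the benzylamine arm of a Bcl-2 series

A few compounds are considered here, and "the series" means these few. Any claim that something is new, unique, unknown or untested is made for them only; others in the source may bear on it.

Measured so far:
compound 1, `Cc1cc(Oc2ccc(Cn3nc4ccc(Cl)cc4c3C(=O)NS(=O)(=O)c3ccc(NCc4ccco4)c([N+](=O)[O-])c3)cc2)cc(C)c1Cl`, 570 nM
compound 2, `Cc1cc(Oc2ccc(Cn3nc4ccc(Cl)cc4c3C(=O)NS(=O)(=O)c3ccc(NCc4ccn(C)n4)c([N+](=O)[O-])c3)cc2)cc(C)c1Cl`, 600 nM
compound 3, `Cc1cc(Oc2ccc(Cn3nc4ccc(Cl)cc4c3C(=O)NS(=O)(=O)c3ccc([N+](=O)[O-])c(NCc4ccco4)c3)cc2)cc(C)c1Cl`, 960 nM

In an assay on isolated protein for inhibition of Apoptosis regulator Bcl-2 (Homo sapiens), read by fluorescence polarization (a lower number here means a stronger inhibitor, a higher number a weaker inhibitor), compound 3 gives 960 nM, the highest of the three numbers; its gaps to compound 2 and to compound 1 both lie within the usual scatter, so the three measured compounds cannot be separated on these data. Compound 4, `Cc1cc(Oc2ccc(Cn3nc4ccc(Cl)cc4c3C(=O)NS(=O)(=O)c3ccc([N+](=O)[O-])c(NCc4ccncc4)c3)cc2)cc(C)c1Cl`, differs from compound 3 in one place: pyridin-4-yl in place of furan-2-yl on a saturated chain carbon bound to a nitrogen on an aromatic ring. Within the data shown here, the only measured step that bears on this change is the exchange of one heteroaryl ring for another on the same kind of chain carbon, a 1.1-fold higher number from compound 1 to compound 2 (0.02 log units; within the scatter), which left the number essentially unchanged. That step was made in a different pair of compounds, and compound 3 itself has no measured partner carrying another ring in that place, so the evidence is thin. On this basis the step to compound 4 is expected to be small, a 1.0-fold lower number from compound 3 to compound 4 (0.00 log units; within the scatter), with no direction beyond the scatter. Compound 4 is therefore estimated at 950 nM in this assay, within a range of 400 nM to 2300 nM.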

Compound 4, inhibition constant: 710 nM
The estimate for compound 4 lay 1.3-fold (0.13 log units) above the measured number; low and high end bracket the measured number.
By their numbers in this assay, from the lowest: compounds 1, 2, 4 and 3 (each within the scatter of the next).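

In this assay, pyridin-4-yl in place of furan-2-yl gives a 1.4-fold lower number from compound 3 to compound 4 (0.13 log units; within the scatter), so on these data a six-membered aromatic ring on this saturated chain carbon cannot be separated from a five-membered one. Among these compounds, this is the first measured ring exchange for compound 3, and no partner for it was available before. Both heteroaryl exchanges now read, this one and a 1.1-fold higher number from compound 1 to compound 2 (0.02 log units; within the scatter), stay within the scatter, although they sit in different pairs of compounds and two exchanges define only a narrow range of rings.

As far as these compounds go, whether a non-aromatic group at this place, such as a piperidine, a carboxylic acid or a longer chain, would move the number beyond the scatter remains open. No measurement shown offers a reason for the result at this place.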